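A few compounds are considered here, and "the series" means these few. Any claim that something is new, unique, unknown or untested is made for them only; others in the source may bear on it.

Measured so far:
compound 1, `COc1cc(/C=C(/Sc2ccc(Br)cc2)C(=O)c2ccc(Br)cc2)ccc1O`: 1000 nM
compound 2, `COc1ccccc1/C=C(\C(=O)c1ccc(Cl)cc1)S(=O)(=O)Cc1ccc(Cl)c(Cl)c1`: 1000 nM

Both were tested in a functional assay on DU-145 cells (Homo sapiens) for inhibition, read by trypan blue exclusion, with a stated time of 96 h; on this read-out higher numbers stand for weaker inhibition of growth and lower numbers for stronger inhibition of growth. Compound 1 stands level with compound 2 at the digits shown; the two values lie within the usual scatter, so neither can be called the stronger. Compound 3, `COc1cc(/C=C(/Sc2ccc(Br)cc2)C(=O)c2ccc(Br)cc2)ccc1F`, is not yet measured. It differs from compound 1 by fluoro in place of hydroxy on an aromatic carbon, exchanging one heavy atom for one heavy atom and removing one hydrogen-bond donor and one hydrogen-bond acceptor. Among the compounds with values here, no measured pair shows this change, so its usual size is unknown here. The step of a 1.6-fold higher number from compound 1 to compound 3 (0.20 log units; within the scatter) is expected to be small, toward weaker inhibition, near the edge of the scatter. Compound 3 is expected to give about 1600 nM, in the range 500 nM to 5000 nM.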

Compound 3, concentration for 50% growth inhibition: 10000 nM
Estimate against measurement, compound 3: 6.3-fold (0.80 log units) below; the whole stated range lies below it.
By their numbers in this assay, from the lowest: compounds 1 and 2 (each within the scatter of the next); then compound 3.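

In this assay this position turns out not to be indifferent: going from 4-hydroxy-3-methoxyphenyl to 4-fluoro-3-methoxyphenyl gives a 10-fold higher number from compound 1 to compound 3 (1.00 log units; beyond the scatter). So, on the core of compound 1, fluoro does not stand in for hydroxy at this place without a real loss of growth inhibition. Nothing available explains why the loss occurs. Within the data shown here, with only this one swap at the position, it remains open whether the hydroxy itself is needed. An amine or a carboxylic acid at the same place could still retain or lose the inhibition.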